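Amide nitrogen substituents on a sulfonamide core in SH-SY5Y cells

A few compounds are considered here, and "the series" means these few. Any claim that something is new, unique, unknown or untested is made for them only; others in the source may bear on it.

Measured compounds:
compound 1, `COc1ccc(Cl)cc1N(CC(=O)Nc1ccccc1)S(=O)(=O)c1ccccc1`, > 20000 nM
compound 2, `COc1ccc(CNC(=O)CN(c2cc(Cl)ccc2OC)S(=O)(=O)c2ccccc2)cc1`, > 20000 nM
compound 3, `COc1ccc(NC(=O)CN(c2cc(Cl)ccc2OC)S(=O)(=O)c2ccccc2)cc1OC`, > 20000 nM

The three measured compounds share one core and differ only in the group on the amide-type nitrogen. In a functional assay on SH-SY5Y cells (Homo sapiens), read by MTT assay, with a stated time of 24 h (on this read-out higher numbers stand for an effect only at larger amounts of compound and lower numbers for an effect already at smaller amounts), compound 1 reaches only the limit of the assay, > 20000 nM. In this assay compound 2 likewise gives a limit, > 20000 nM. Compound 3 also stands at a limit, > 20000 nM, so no number is known for it, and the two other values shown are limits as well; this is summed up by the limit of > 20000 nM in this assay, at which 3 of the 3 values shown sit. The steps a step that the two limits leave unreadable from compound 1 to compound 3 and a step that the two limits leave unreadable from compound 2 to compound 3 therefore cannot be read in size.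

Compound 4, `COc1ccc(Cl)cc1N(CC(=O)Nc1ccc([N+](=O)[O-])cc1)S(=O)(=O)c1ccccc1`, differs from compound 3 by 4-nitrophenyl in place of 3,4-dimethoxyphenyl on an amide-type nitrogen. The steps leading to compound 3 bear on this change but are unreadable, so no direction beyond the scatter can be inferred. Compound 4 is expected to give 25000 nM, within 8000 nM to 80000 nM, most likely again as a limit. The estimated step is then a step that the limit leaves unreadable from compound 3 to compound 4, that is, no readable change.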

Compound 4, half-maximal effective concentration: 8210 nM
Estimate against measurement, compound 4: 3.0-fold (0.48 log units) above, and the stated range covers the measured number.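

In this assay the group on the amide-type nitrogen proves able to move the read-out: with 4-nitrophenyl the series gives its first readable number, and the change from 3,4-dimethoxyphenyl is an at least 2.4-fold lower number from compound 3 to compound 4 (0.38 log units; beyond the scatter). 4-Nitrophenyl in place of 4-methoxybenzyl gives an at least 2.4-fold lower number from compound 2 to compound 4 (0.38 log units; beyond the scatter), and nitro in place of hydrogen on an aromatic carbon, the smallest change of the three, gives an at least 2.4-fold lower number from compound 1 to compound 4 (0.38 log units; beyond the scatter). The steps among the other compounds still cannot be read, as all of them remain at the limit: the limit of > 20000 nM in this assay, at which 3 of the 4 values shown sit.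

From the compounds shown here alone, the full size of the new steps stays open, with only one end of each a number. Also open, going by these compounds, is whether this effect is particular to nitro, or whether a nitrile or an amine in its place would give a readable number as well.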